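The compounds below may be only part of what the source reports. "The series", "measured", "known", "first", "only" and "open" are said of these compounds alone.

Measured compounds:
compound 1, `O=C1C(=O)N(CCCCn2cc(COc3cc(=O)oc4ccccc34)nn2)c2ccc(Br)cc21`: 59%
compound 2, `O=C1C(=O)N(CCCCn2cc(COc3cc(=O)oc4ccccc34)nn2)c2ccc(Cl)cc21`: 62%
compound 3, `O=C1C(=O)N(CCCn2cc(COc3cc(=O)oc4ccccc34)nn2)c2ccc(Br)cc21`: 66%

All three were tested in a functional assay on HCT-116 cells (Homo sapiens) for inhibition, read by sulforhodamine B assay, with a stated time of 48 h, tested at 50 uM; on this read-out higher numbers stand for more inhibition of growth at the one concentration tested and lower numbers for less inhibition of growth. Compound 1 gives 59% and compound 2 gives 62%; the two differ by one change only, (chloro in place of bromo on an aromatic carbon), and the step that goes with it is a number 3 percentage points higher from compound 1 to compound 2 (within the scatter). Compound 3 gives 66% in this assay, and its two neighbours sit within the scatter of it. How the core of compound 3 differs from the core of compound 1 is not broken down here.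

The compound still to be measured is compound 4, `O=C1C(=O)N(CCCn2cc(COc3cc(=O)oc4ccccc34)nn2)c2ccc(Cl)cc21`. It stands to compound 3 as compound 2 stands to compound 1: the change is chloro in place of bromo on an aromatic carbon, and the place it sits is the same in both pairs word for word, so it is the same change made a second time. For the measured compounds named here, the only guide to its size is the earlier pair, where a number 3 percentage points higher from compound 1 to compound 2 (within the scatter), a step that does not leave the scatter. On that basis the step from compound 3 to compound 4 is expected to be a number 2 percentage points higher from compound 3 to compound 4 (within the scatter), resting on a number 3 percentage points higher from compound 1 to compound 2 (within the scatter) and on the value of compound 3, 66%. Compound 4 is therefore estimated to give 68% in this assay, with an expected range from 58% to 78%.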

Compound 4, percent growth inhibition at one concentration: 68%
Compound 4: middle estimate and measured number agree at the digits printed; the measured number falls inside the stated range.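

In this assay, putting chloro in place of bromo on the second core gives a number 2 percentage points higher from compound 3 to compound 4 (within the scatter) and so repeats the earlier result, as the two steps side by side show: the same change on two cores in this assay, a number 3 percentage points higher (within the scatter) from compound 1 to compound 2 and a number 2 percentage points higher (within the scatter) from compound 3 to compound 4, 1 percentage points apart, within the scatter of two such steps. Within these four compounds, then, the change carries from one core to the other without any difference that can be told apart from the scatter, so the step seen on the first core served as a fair guide to the step on the second. It does not show that chloro is better than bromo, since each step on its own stays within the scatter, and two pairs read at a single concentration in one cell line say nothing about whether the change would behave the same way on any other core.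

The compounds shown leave open how a fluoro, a methyl or a methoxy group on that aromatic carbon would compare with chloro and bromo, and whether any of them would produce a step that leaves the scatter. They also leave open whether a longer chain, or an amine placed in the chain, would alter the size of this step.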